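Methyl for fluoro on the benzyl ring of a bombesin receptor subtype-3 agonist

The compounds below may be only part of what the source reports. "The series", "measured", "known", "first", "only" and "open" are said of these compounds alone.

Compound 1 `O=C(O)c1ccccc1-c1ccc(CCc2ncc(Cc3ccccc3Cl)[nH]2)cc1` gives 22 nM in an in vitro functional assay on cells for agonist activity at Bombesin receptor subtype-3 (Mus musculus), read by luminescence and calcium flux; on this read-out higher numbers stand for an effect only at larger amounts of compound and lower numbers for an effect already at smaller amounts. Among the measured compounds shown here, compound 2 `O=C(O)c1ccccc1-c1ccc(CCc2ncc(Cc3ccc(F)cc3)[nH]2)cc1` gives 50 nM in this assay, and the one measured step, a 2.3-fold higher number from compound 1 to compound 2 (0.36 log units; beyond the scatter), came with a change of the whole aryl group. Compound 2 therefore holds the highest of the two numbers seen so far, with compound 1 the nearer and lower one.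

Compound 3 `Cc1ccc(Cc2cnc(CCc3ccc(-c4ccccc4C(=O)O)cc3)[nH]2)cc1` differs from compound 2 by methyl in place of fluoro on an aromatic carbon. For the measured compounds named here, no measured step exchanges one substituent for another on the same ring, so the only step available, a 2.3-fold higher number from compound 1 to compound 2 (0.36 log units; beyond the scatter), bears on it loosely, and it was itself modest. A change of this kind is expected to give a step near or within the scatter, in no firm direction, namely no change at the digits printed from compound 2 to compound 3 (within the scatter). Compound 3 is thus estimated at 50 nM, between 20 nM and 125 nM.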

Compound 3, half-maximal effective concentration: 162 nM
For compound 3 the middle estimate is 3.2-fold (0.51 log units) below the measured one, and the stated range ends below it.
By their numbers in this assay, from the lowest: compound 1; then compound 2; then compound 3.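

In this assay, replacing fluoro with methyl on the ring, para to a large group, is not a neutral exchange: a 3.2-fold higher number from compound 2 to compound 3 (0.51 log units; beyond the scatter), even though one heavy atom leaves, one enters and the hydrogen-bond donor and acceptor counts stay the same. Measured against the 2-chlorophenyl group, the 4-methylphenyl group gives a 7.4-fold higher number from compound 1 to compound 3 (0.87 log units; beyond the scatter), which places compound 3 highest of the three on this read-out, with both of its steps beyond the scatter. Nothing available explains why methyl and fluoro differ here.

The compounds shown leave open how other groups at this same place, such as methoxy or trifluoromethyl, would read. Compound 1 carries a different group in a different place on the ring, so the separate contributions of group and place to its lower number remain unresolved.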